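The source may hold more compounds than are shown below. What is called first, only, known or untested is meant among the compounds shown, and "the series" means these compounds.

In an assay on isolated protein for inhibition of Ephrin type-B receptor 4 (Homo sapiens), read by HTRF, tested at 10 uM (on this read-out lower numbers stand for less inhibition and higher numbers for more inhibition at the one concentration tested (going by the name of the read-out)), the measured compounds stand as follows: compound 1 `COC[C@@H]1CCCN1C(=O)C1CCCN1c1cc(Nc2cccc(Br)c2)ncn1` gives 0%; compound 2 `Cc1cccc(N(C)c2cc(Nc3cccc(C(=O)N(CC(C)C)CC(C)C)c3)ncn2)c1` gives 0%; compound 3 `CN(CCCn1ccnc1)C(=O)[C@@H]1CCCN1c1nccc(Nc2ccccc2)n1` gives 0%.

Compound 3 thus stands level with compound 1 and compound 2 at the digits shown; its nearest neighbour is compound 1 and its furthest is compound 2, and both gaps lie within the scatter, so none of the three can be ordered against the others. Compound 4 `COC[C@@H]1CCCN1C(=O)[C@@H]1CCCN1c1nccc(Nc2ccccc2)n1` differs from compound 3 in one place: 2-(methoxymethyl)pyrrolidin-1-yl in place of (3-(1H-imidazol-1-yl)propyl)(methyl)amino on a carbonyl carbon. Among the compounds with values here, no step between measured compounds covers this change. Since compound 1 already carries the 2-(methoxymethyl)pyrrolidin-1-yl group and gives 0%, the expected step of a number 2 percentage points higher from compound 3 to compound 4 (within the scatter) is none beyond the scatter. Compound 4 is estimated at 2%, with a range from -8% to 15%.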

Compound 4, a percentage reported as inhibition, at one concentration (the size of the read-out at that concentration, not a potency): 0%
Compound 4: middle estimate off by 2 percentage points, on the high side, within the range that was stated.
By their numbers in this assay, from the lowest: compounds 1, 2, 3 and 4 (each within the scatter of the next).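

In this assay, exchanging the group on the carbonyl carbon gives no change at the digits printed from compound 3 to compound 4 (within the scatter), so neither group yields a readable signal on this shared core. With the two compounds level, the step cannot show whether this position influences inhibition at all, and no evidence is available to interpret it. From the compounds shown here alone, whether a piperazine or a morpholine on that carbonyl carbon would give a different reading remains open. So does the effect of this change on any compound with measurable inhibition.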